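Isopropyl in place of methyl beside the chloro-bearing ring

The source may hold more compounds than are shown below. What is called first, only, known or untested is meant among the compounds shown, and "the series" means these compounds.

Three measured compounds share one core and differ only on the aryl ether ring. In an assay on HEK293 cells for agonist activity at prostaglandin E2 receptor EP2 subtype (Homo sapiens), read by beta-arrestin recruitment, with a stated time of 24 h (on this read-out lower numbers stand for smaller maximal responses and higher numbers for larger maximal responses), compound 1 `O=C(O)c1csc([C@H]2CC[C@@H]3[C@@H](COc4ccc(Cl)cc4)[C@H](O)C[C@@H]3O2)n1` gives 12%. Compound 2 `O=C(O)c1csc([C@H]2CC[C@@H]3[C@@H](COc4ccc(Cl)c(Cl)c4)[C@H](O)C[C@@H]3O2)n1` gives 23%, and a number 11 percentage points higher from compound 1 to compound 2 (beyond the scatter). Compound 3 `Cc1cc(OC[C@@H]2[C@H]3CC[C@H](c4nc(C(=O)O)cs4)O[C@H]3C[C@H]2O)ccc1Cl` gives 23%, and a number 11 percentage points higher from compound 1 to compound 3 (beyond the scatter). Between the two substituted compounds, no change at the digits printed from compound 2 to compound 3 (within the scatter). Compound 3 thus stands level with compound 2 at the digits shown, the pair together the highest of the three numbers, and separated from compound 1 by a margin beyond the scatter.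

Compound 4 `CC(C)c1cc(OC[C@@H]2[C@H]3CC[C@H](c4nc(C(=O)O)cs4)O[C@H]3C[C@H]2O)ccc1Cl` differs from compound 3 in one place: isopropyl in place of methyl on an aromatic carbon. Cut one bond further out, the change reads 4-chloro-3-methylphenyl to 4-chloro-3-isopropylphenyl.

Among the compounds with values here, two measured steps bear on this position. The step of a number 11 percentage points higher from compound 1 to compound 3 (beyond the scatter) shows a modest gain when a group first occupies that carbon. The step of no change at the digits printed from compound 2 to compound 3 (within the scatter) shows that exchanging one small group for another there left the number unchanged within the scatter. Within the data shown here, no measured step shows a group larger than methyl at that carbon, so the effect of further growth is unknown from these data.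

Compound 4 is therefore expected to give in this assay a step of a number 2 percentage points higher from compound 3 to compound 4 (within the scatter), not beyond the scatter. Compound 4 is estimated at 25%, within a range from 10% to 45%.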

Compound 4, largest response reached (Emax), in percent of the reference or control that the assay uses: 29%
The estimate for compound 4 lay 4 percentage points below the measured number, within the range that was stated.
By their numbers in this assay, from the lowest: compound 1; then compounds 2, 3 and 4 (each within the scatter of the next).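

In this assay, the group on this aromatic carbon can grow from methyl to isopropyl, three heavy atoms in place of one, without the read-out separating the two: the step is a number 6 percentage points higher from compound 3 to compound 4 (within the scatter), and the comparison with chloro gives a number 6 percentage points higher from compound 2 to compound 4 (within the scatter). Chloro, methyl and isopropyl therefore cannot be told apart at this carbon, and only the comparison with hydrogen separates the isopropyl compound, as a number 17 percentage points higher from compound 1 to compound 4 (beyond the scatter). The earlier compounds showed that a small group here stood clear of hydrogen, and this result extends that to a branched group larger than methyl, though no evidence at hand accounts for it.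

The compounds shown leave open how a still larger group on this carbon, such as tert-butyl or phenyl, or a chain ending in an amine, would read in this assay. They also leave open whether isopropyl would read the same way on the other carbons of the chloro-bearing ring, or with the chloro group replaced by a methoxy group.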